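Adding a methyl to the amine of compound 2

A few compounds are considered here, and "the series" means these few. Any claim that something is new, unique, unknown or untested is made for them only; others in the source may bear on it.

Compound 1 `CN(C)c1cccc(NC(=O)C(=O)O)c1C#N` gives 54.7% in a functional assay on the whole organism for inhibition, with Rattus norvegicus as the target, at a dose of 1 mg/kg by the oral route; a lower number here means less inhibition, a higher number more inhibition at the dose given (going by the name of the read-out).
Compound 2 `CCNc1cccc(NC(=O)C(=O)O)c1C#N` gives 58.9% in this assay.

Among the measured compounds shown here, only two compounds have been measured, both sharing the same core with an aromatic amine substituent beside a common oxamic acid side chain. For the measured compounds named here, the one step so far, a number 4.2 percentage points higher from compound 1 to compound 2 (within the scatter), did not move the read-out beyond the scatter, so compound 2 stands at the top of the two numbers only nominally; its value and that of compound 1 cannot be told apart.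

Compound 3 `CCN(C)c1cccc(NC(=O)C(=O)O)c1C#N` differs from compound 2 by methyl in place of hydrogen on a nitrogen on an aromatic ring. The resulting amine carries the ethyl of compound 2 together with a methyl as in compound 1, so compound 3 lies between the two measured compounds in this respect. Going by the values given here, the only step that bears on it, from dimethylamino to ethylamino, was within the scatter, so no step beyond the scatter is expected here either. The expected step of a number 2.9 percentage points lower from compound 2 to compound 3 (within the scatter) is therefore small and slightly downward. Compound 3 is expected to give about 56% in this assay, in a range from 44% to 68%.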

Compound 3, a percentage reported as inhibition, in the whole organism at one dose (the size of the read-out at that dose, not a potency): 56.3%
The estimate for compound 3 lay 0.3 percentage points below the measured number; measured number inside the range.
By their numbers in this assay, from the lowest: compounds 1, 3 and 2 (each within the scatter of the next).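

In this assay, methyl in place of hydrogen on the nitrogen gives a number 2.6 percentage points lower from compound 2 to compound 3 (within the scatter), and methyl in place of hydrogen on the saturated chain carbon bound to that nitrogen gives a number 1.6 percentage points higher from compound 1 to compound 3 (within the scatter). The earlier step changed both features at once, whereas these two steps change each one alone, and neither moves the read-out beyond the scatter. Across these three compounds, the read-out therefore does not separate an amine nitrogen that keeps its hydrogen from one that carries two carbon groups, nor a methyl from an ethyl on that nitrogen, and no measurement at hand explains this insensitivity.

Going by these compounds, it remains open whether a longer chain such as propyl, a ring amine such as pyrrolidine or an unsubstituted amino group in this place would also stay within the scatter or would move the number clearly. These readings also come from a single oral dose, so they give the size of the inhibition at that dose and not a potency, and whether the compounds would separate at another dose is open too.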